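A few compounds are considered here, and "the series" means these few. Any claim that something is new, unique, unknown or untested is made for them only; others in the source may bear on it.

Of the compounds shown here, three sharing one core have been measured so far. Compound 1 `COc1ccc2c(=O)c(/C=C/C(=O)NCc3ccccc3)coc2c1` carries a benzyl group on the amide-type nitrogen. In a functional assay (QGY7701 cells, Homo sapiens) for inhibition, read by MTT assay, with a stated time of 48 h (a higher number here means a weaker inhibitor, a lower number a stronger inhibitor), compound 1 gives > 100000 nM, which is a limit of the assay rather than a number. Compound 2 `COc1cccc(NC(=O)/C=C/c2coc3cc(OC)ccc3c2=O)c1` carries a 3-methoxyphenyl on the amide-type nitrogen, and in this assay compound 2 gives 39100 nM; the step of an at least 2.5-fold lower number from compound 1 to compound 2 (0.40 log units; beyond the scatter) follows. Compound 3 `COc1ccc2c(=O)c(/C=C/C(=O)NCc3ccc(F)cc3)coc2c1` carries a 4-fluorobenzyl, and in this assay compound 3 gives 7960 nM, the lowest of the two numbers, with compound 2 the nearest. The measured steps are an at least 12-fold lower number from compound 1 to compound 3 (1.09 log units; beyond the scatter) and a 4.9-fold lower number from compound 2 to compound 3 (0.69 log units; beyond the scatter).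

Compound 4 `COc1ccc(CNC(=O)/C=C/c2coc3cc(OC)ccc3c2=O)cc1` differs from compound 3 by methoxy in place of fluoro on an aromatic carbon. Among the compounds with values here, no measured step swaps methoxy for fluoro at this place. The step of an at least 12-fold lower number from compound 1 to compound 3 (1.09 log units; beyond the scatter) shows that a group in this place matters; whether methoxy gives as much as fluoro is not told, and compound 2 carries its methoxy on a 3-methoxyphenyl, not on a benzyl. Compound 4 is therefore expected to show a 1.9-fold higher number from compound 3 to compound 4 (0.28 log units; within the scatter), a somewhat higher number. The estimate for compound 4 in this assay is 15000 nM, between 4000 nM and 60000 nM.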

Compound 4, half-maximal inhibitory concentration: 15700 nM
Beside the measured number, compound 4's estimate is 1.0-fold (0.02 log units) below it, and the stated range covers the measured number.
By their numbers in this assay, from the lowest: compounds 3 and 4 (each within the scatter of the next); then compound 2. At a limit, above all of these: compound 1.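

In this assay, methoxy and fluoro on an aromatic carbon para to a large group cannot be told apart, with a 2.0-fold higher number from compound 3 to compound 4 (0.29 log units; within the scatter), while a 2.5-fold lower number from compound 2 to compound 4 (0.40 log units; beyond the scatter) shows that the gap to the 3-methoxyphenyl amide of compound 2 persists when both compounds carry a methoxy group. The lower number seen with fluoro over hydrogen is therefore not confined to fluoro, since methoxy in place of hydrogen gives an at least 6.3-fold lower number from compound 1 to compound 4 (0.80 log units; beyond the scatter). That step is only a bound because compound 1 stands at a limit: the limit of > 100000 nM in this assay, at which 1 of the 4 values shown sits.

The compounds shown leave open whether other groups at this place, such as chloro, hydroxy or a dimethylamino group, would stay in the range of compound 3 and compound 4, and whether the same groups would behave alike elsewhere on the benzyl ring. They also leave open how much of the gap to compound 2 rests on the methylene link and how much on where the methoxy sits, which a 4-methoxyphenyl amide or a longer chain such as phenethyl on the nitrogen would separate.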